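The compounds below may be only part of what the source reports. "The series", "measured", "known", "first", "only" and "open" are said of these compounds alone.

Of the compounds shown here, two built on the same core have been measured in a functional assay on MG-63 cells (Homo sapiens) for inhibition, read by CCK-8 assay, with a stated time of 72 h, tested at 1 uM; a lower number here means less inhibition, a higher number more inhibition at the concentration tested (going by the name of the read-out). Compound 1 `O=C(NCCCCc1ccccc1)c1cccc(C2SCC(=O)N2c2cccc(F)c2)c1` gives 92% in this assay. Compound 2 `CCOc1ccccc1N1C(=O)C(C)SC1c1cccc(C(=O)NCCCCc2ccccc2)c1` gives 92% in this assay; the two readings are level at the digits shown and lie within the usual scatter of the method, so neither can be called stronger than the other. For the measured compounds named here, no pair of measured compounds differs at only a single place, so no measured step is available to guide the next move. Compound 3 `COc1ccc(F)cc1N1C(=O)CSC1c1cccc(C(=O)NCCCCc2ccccc2)c1` is not yet measured. It differs from compound 1 in one spot: methoxy in place of hydrogen on an aromatic carbon. Because compound 1 already gives 92% in this assay, near the top of what this read-out can show, the step of a number 4 percentage points lower from compound 1 to compound 3 (within the scatter) is expected to be small, at most a modest fall, and within the scatter. Compound 3 is therefore estimated at 88%, in a range from 70% to 96%.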

Compound 3, a percentage reported as inhibition, at one concentration (the size of the read-out at that concentration, not a potency): 86%
Estimate against measurement, compound 3: 2 percentage points above; the measured number falls inside the stated range.
By their numbers in this assay, from the lowest: compounds 3, 1 and 2 (each within the scatter of the next).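

Swapping hydrogen for methoxy on an aromatic carbon, ortho to a large group and para to a fluoro group, gives a number 6 percentage points lower from compound 1 to compound 3 (within the scatter) in this assay. For the compounds shown here, this is the first comparison here that isolates a single change, and it shows that the position accepts the methoxy group without a difference that can be told from the scatter. As the read-out is a size at one concentration rather than a potency, it does not show whether the two compounds would also match at lower concentrations. Nothing measured alongside these compounds bears on this step.

On these data alone, it remains open how this position would respond to a group of another kind, such as an amine or a carboxylic acid. As far as these compounds go, it is also open whether the methoxy group would be accepted in the same way with the fluoro group replaced by hydrogen.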